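The source may hold more compounds than are shown below. What is called first, only, known or untested is meant among the compounds shown, and "the series" means these compounds.

For the measured compounds named here, in an ADME assay on CCRF-HSB-2 cells (Homo sapiens) for cytotoxicity, with a stated time of 7 days (a higher number here means that more compound is tolerated, a lower number that less compound is tolerated), compound 1 `CCCCSc1nc(N)nc2c1ncn2/C=C1/CC1(CO)CO` gives 89000 nM, the only plain number among the three values shown. Compound 2 `Nc1nc(NC2CC2)c2ncn(/C=C3/CC3(CO)CO)c2n1` stops at a limit of this assay, > 20000 nM. Compound 3 `CCCNc1nc(N)nc2c1ncn2/C=C1/CC1(CO)CO` likewise stops at a limit, > 20000 nM. With the limit of > 20000 nM in this assay, at which 2 of the 3 values shown sit, the step that the limit leaves unreadable from compound 1 to compound 2 and the step that the limit leaves unreadable from compound 1 to compound 3 cannot be read in size, and neither can a step that the two limits leave unreadable from compound 2 to compound 3. Compound 4 `CC(C)CNc1nc(N)nc2c1ncn2/C=C1/CC1(CO)CO` differs from compound 1 in one place: isobutylamino in place of butylsulfanyl on an aromatic carbon. The measured steps that bear on this change are the two that also swap butylsulfanyl for an amino group, and both run into a limit, so they give no readable size and no direction beyond the usual scatter; the most that can be said is that both amino compounds were tolerated up to the limit. For compound 4 the value in this assay is therefore expected to be 80000 nM, within a range from 20000 nM to 300000 nM, most likely again reported only as a limit. This expectation amounts to a step of a 1.1-fold lower number from compound 1 to compound 4 (0.05 log units; within the scatter).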

Compound 4, half-maximal cytotoxic concentration: > 20000 nM
Compound 4 ended at the assay's limit (the forecaster's own chance of this, stated with the estimate: 70%); the middle value does not contradict the limit.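

Compound 4 stops at a limit of the assay, so none of its steps from compound 1, compound 2 or compound 3 can be read in size: the limit of > 20000 nM in this assay, at which 3 of the 4 values shown sit. From the compounds shown here alone, what remains open is how far compound 2, compound 3 and compound 4 truly differ from one another and from compound 1 in this assay.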